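The source may report more compounds than this note shows. Statements on the series, on what has been measured and on what is new or still open speak of the compounds shown alone.

In a functional assay on HeLa cells (Homo sapiens) for inhibition, read by sulforhodamine B assay (on this read-out higher numbers stand for weaker inhibition and lower numbers for stronger inhibition), compound 1 `O=C1C(NC2CCCC2)=CC(=O)c2c1nc1n2[C@H]2OC[C@@H](O)[C@H]2OC1` gives > 16000 nM. That figure is a limit of the assay and not a true number, so the position of compound 1 is only loosely known. Compound 2 `O=C1C=C(Nc2cccc(F)c2)C(=O)c2c1nc1n2[C@H]2OC[C@@H](O)[C@H]2OC1` does give a number in this assay, namely 6440 nM.

The step followed here leads to compound 3 `O=C1C(Nc2ccc(C(F)(F)F)cc2)=CC(=O)c2c1nc1n2[C@H]2OC[C@@H](O)[C@H]2OC1`, which carries 4-(trifluoromethyl)phenyl in place of cyclopentyl on an amine nitrogen. Among the compounds with values here, no measured step shows what this swap does. Within the data shown here, a modest move towards stronger inhibition in this assay is nevertheless expected, an expectation that rests on compound 2 at 6440 nM, the only true number available. Compound 3 could still end up reported only as a limit. The estimated step is an at least 2.2-fold lower number from compound 1 to compound 3 (0.35 log units; beyond the scatter). For compound 3 the expected value is 7000 nM, with an estimated range from 2500 nM to 20000 nM.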

Compound 3, half-maximal inhibitory concentration: 8920 nM
Estimate against measurement, compound 3: 1.3-fold (0.11 log units) below; the measured number falls inside the stated range.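

Replacing cyclopentyl with 4-(trifluoromethyl)phenyl on an amine nitrogen gives, in this assay, an at least 1.7-fold lower number from compound 1 to compound 3 (0.25 log units; that floor lies within the scatter). Within the data shown here, this is the first view of an aromatic ring at this position in a direct one-place comparison, and the larger group still gives a true reading rather than a limit, so the position accepts this aromatic group without the number rising out of range. On these data alone, the real size of the step stays unknown, and its floor alone does not establish a gain in strength, because compound 1 is reported only as a limit: the limit of > 16000 nM in this assay, at which 1 of the 3 values shown sits.

The compounds shown leave open what a plain phenyl or a hexyl chain on this nitrogen would give. It therefore remains unclear whether the aromatic ring or the trifluoromethyl group accounts for the change.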